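From a Nitrile Aryl to a Difluorophenyl on the Cyclopropane

The source may hold more compounds than are shown below. What is called first, only, known or untested is meant among the compounds shown, and "the series" means these compounds.

Three compounds built on one shared core have been examined in a functional assay for agonist activity at G protein-coupled receptor 88 (Homo sapiens), read by HTRF and cAMP accumulation; on this read-out lower numbers stand for an effect already at smaller amounts and higher numbers for an effect only at larger amounts of compound. Compound 1, `CC[C@H](C)[C@H](N)CN(C(=O)[C@@H]1C[C@H]1c1cccc(OC)c1)c1ccc(-c2ccccc2)cc1`, gives 3000 nM. Compound 2, `CC[C@H](C)[C@H](N)CN(C(=O)[C@@H]1C[C@H]1c1cccc(C)c1)c1ccc(-c2ccccc2)cc1`, gives 1200 nM. Compound 3, `CC[C@H](C)[C@H](N)CN(C(=O)[C@@H]1C[C@H]1c1ccc(C#N)cc1)c1ccc(-c2ccccc2)cc1`, reaches only a limit of the assay, > 25000 nM, so its place among the three is known as a boundary rather than a number, at the limit of > 25000 nM in this assay, at which 1 of the 3 values shown sits. The steps into compound 3 are large: an at least 8.3-fold higher number from compound 1 to compound 3 (0.92 log units; beyond the scatter) and an at least 20-fold higher number from compound 2 to compound 3 (1.31 log units; beyond the scatter). Between the two numbered compounds the step is a 2.5-fold lower number from compound 1 to compound 2 (0.40 log units; beyond the scatter).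

Compound 4, `CC[C@H](C)[C@H](N)CN(C(=O)[C@@H]1C[C@H]1c1cc(F)cc(F)c1)c1ccc(-c2ccccc2)cc1`, is the compound still to be measured. Its change from compound 3 is 3,5-difluorophenyl in place of 4-cyanophenyl on a saturated ring carbon. The measured steps that bear on it are an at least 8.3-fold higher number from compound 1 to compound 3 (0.92 log units; beyond the scatter) and an at least 20-fold higher number from compound 2 to compound 3 (1.31 log units; beyond the scatter), both running toward the 4-cyanophenyl group and both beyond the scatter; compound 4 runs away from that group, though toward a substituent pattern not yet seen on this core. In this assay a lower number is therefore expected, estimated as an at least 6.2-fold lower number from compound 3 to compound 4 (0.79 log units; beyond the scatter). Compound 4 is estimated at 4000 nM, with an expected range from 800 nM to 25000 nM, and a real chance remains that it again sits only at the limit.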

Compound 4, half-maximal effective concentration: 960 nM
Estimate against measurement, compound 4: 4.2-fold (0.62 log units) above; measured number inside the range.
By their numbers in this assay, from the lowest: compounds 4 and 2 (each within the scatter of the next); then compound 1. At a limit, above all of these: compound 3.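

In this assay, the change from 2-(4-cyanophenyl)cyclopropyl to 2-(3,5-difluorophenyl)cyclopropyl on the shared core gives an at least 26-fold lower number from compound 3 to compound 4 (1.41 log units; beyond the scatter). Going by these compounds, the value of compound 3 is only a limit, so the true size of that step stays unknown: the limit of > 25000 nM in this assay, at which 1 of the 4 values shown sits. The step of a 1.3-fold lower number from compound 2 to compound 4 (0.10 log units; within the scatter) and the step of a 3.1-fold lower number from compound 1 to compound 4 (0.49 log units; beyond the scatter) show that this saturated ring carbon accepts a phenyl ring with two fluorines at a level that cannot be told apart from 3-methylphenyl and that improves on 3-methoxyphenyl, so three of the four aryl groups now give measured numbers, with compound 3 the one that goes against this.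

The 4-cyanophenyl group differs from the other three aryl groups both in its substituent and in where that substituent sits, so the compounds shown cannot say which of the two accounts for the limit reached by compound 3. They also leave open how a single fluorine, a chlorine, a trifluoromethyl group, an amine or a carboxylic acid on this phenyl ring would read in this assay.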